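Chloro on the second aryl ring of compound 3

The source may hold more compounds than are shown below. What is called first, only, known or untested is meant among the compounds shown, and "the series" means these compounds.

Measured so far in a functional assay on CHO cells for agonist activity at adenosine receptor A1 (Homo sapiens), read by fluorescence and ERK phosphorylation, with stated times of 30 min and 1.5 h, tested at 3 uM; on this read-out higher numbers stand for a stronger effect at the one concentration tested and lower numbers for a weaker effect:
compound 1, `Nc1scc(-c2ccc(Cl)cc2)c1C(=O)c1ccccc1`, 46%
compound 2, `Nc1scc(-c2ccc(Br)cc2)c1C(=O)c1ccccc1`, 46%
compound 3, `COc1ccc(-c2csc(N)c2C(=O)c2ccccc2)cc1`, 52%

Compound 3 sits within the scatter of both other numbers: a number 6 percentage points higher from compound 1 to compound 3 (within the scatter) and a number 6 percentage points higher from compound 2 to compound 3 (within the scatter), and also no change at the digits printed from compound 1 to compound 2 (within the scatter). All three measured steps exchange one substituent on the same aryl ring for another, and none of them moves the read-out beyond the scatter.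

Compound 4, `COc1ccc(-c2csc(N)c2C(=O)c2ccc(Cl)cc2)cc1`, differs from compound 3 at a different place: chloro in place of hydrogen on an aromatic carbon. Among the measured compounds shown here, no measured step touches this ring, so nothing directly bears on the change, and the only guidance is that every substituent exchange so far has left this assay unmoved. Adding a halogen to this second ring is therefore expected to give no step beyond the scatter, a number 2 percentage points lower from compound 3 to compound 4 (within the scatter).

Compound 4 is estimated in this assay at 50%, expected to fall between 35% and 65%.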

Compound 4, a percentage reported as activity, at one concentration (the size of the read-out at that concentration, not a potency): 51%
Estimate against measurement, compound 4: 1 percentage points below; low and high end bracket the measured number.
By their numbers in this assay, from the lowest: compounds 1, 2, 4 and 3 (each within the scatter of the next).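

In this assay, among the compounds shown here, the phenyl to 4-chlorophenyl change gives a number 1 percentage points lower from compound 3 to compound 4 (within the scatter) and is the first step read on the second aryl ring. A chloro para to a large group on this ring therefore leaves the read-out within the scatter, as the exchanges of chloro, bromo and methoxy on the other aryl ring did. Nothing at hand gives a reason for this flat result.

Open, on these data alone, is whether an amine, a carboxylic acid or a longer chain at this same place on the second aryl ring would also stay within the scatter. Also open, as far as these compounds go, is whether compound 3 and compound 4 would still match in potency, since this read-out gives the size of the effect at one concentration only.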